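Trading methyl for trifluoromethyl on a growth inhibitor

A few compounds are considered here, and "the series" means these few. Any claim that something is new, unique, unknown or untested is made for them only; others in the source may bear on it.

Among the compounds with values here, in a functional assay on U-251 cells (Homo sapiens) for inhibition, read by sulforhodamine B assay, with a stated time of 48 h, tested at 50 uM (on this read-out higher numbers stand for more inhibition of growth at the one concentration tested and lower numbers for less inhibition of growth), compound 1 (`Cc1ccc(F)c(C(=O)c2ccc3nc(NC(=O)C(F)(F)F)cn3c2)c1`) stands highest so far with 61.5% while compound 2 (`Cc1ccc(C(=O)c2ccc3nc(NC(=O)C(F)(F)F)cn3c2)cc1F`) gives 37.9% as the only other number. Compound 3 (`O=C(c1ccc2nc(NC(=O)C(F)(F)F)cn2c1)c1cc(C(F)(F)F)ccc1F`) has trifluoromethyl in place of methyl on an aromatic carbon para to a fluoro group. Within the data shown here, the one measured step (a number 23.6 percentage points lower from compound 1 to compound 2 (beyond the scatter)) is modest and beyond the scatter, yet it moves the fluoro and methyl groups and exchanges neither, so it bears only indirectly. The expected step (a number 6.5 percentage points lower from compound 1 to compound 3 (within the scatter)) is therefore smaller and downward. Compound 3 is estimated at 55% (range 35% to 75%).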

Compound 3, percent growth inhibition at one concentration: 59.3%
Beside the measured number, compound 3's estimate is 4.3 percentage points below it; the range from low to high includes it.
By their numbers in this assay, from the lowest: compound 2; then compounds 3 and 1 (each within the scatter of the next).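

In this assay, trifluoromethyl in place of methyl on this aromatic carbon, para to a fluoro group, gives a number 2.2 percentage points lower from compound 1 to compound 3 (within the scatter), so four heavy atoms stand where one stood with no difference the read-out can separate from scatter. The earlier pair showed only a rearrangement of the fluoro and methyl groups, whereas this exchange replaces the group itself at this position. No measurement here explains why the two groups read alike. From the compounds shown here alone, whether an amine or a nitrile at this position would read alike remains open, as does whether the same exchange would hold on the arrangement of compound 2.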